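The source may hold more compounds than are shown below. What is called first, only, known or untested is meant among the compounds shown, and "the series" means these compounds.

Measured compounds:
- compound 1, `COc1ccc(CNC(=O)/C(C#N)=C/c2ccc[nH]2)cc1`: 34000 nM
- compound 2, `COc1ccc(CNC(=O)/C(C#N)=C/c2ccc(Cl)o2)cc1`: 9000 nM
- compound 3, `COc1ccc(CNC(=O)/C(C#N)=C/c2ccc3ccccc3c2)cc1`: 33000 nM

In a functional assay on MCF7 cells (Homo sapiens) for inhibition, read by MTT assay, with a stated time of 72 h (a higher number here means a weaker inhibitor of growth, a lower number a stronger inhibitor of growth), compound 3 gives 33000 nM, the second highest of the three numbers. Compound 1 gives 34000 nM, which lies within the scatter of compound 3, so the two cannot be told apart. Compound 2 gives 9000 nM, a lower number beyond the scatter.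

Compound 4 is `N#C/C(=C\c1ccc2ccccc2c1)C(=O)NCc1ccc(Cl)c(Cl)c1`. It differs from compound 3 in one place: 3,4-dichlorophenyl in place of 4-methoxyphenyl on a saturated chain carbon bound to an amide-type nitrogen. Among the measured compounds shown here, the only measured step, a 3.8-fold lower number from compound 1 to compound 2 (0.58 log units; beyond the scatter), concerns a different part of the molecule, the aromatic group on the double-bonded chain carbon, and says nothing about the group on the saturated chain carbon bound to the amide-type nitrogen. For the measured compounds named here, no measured pair varies that position. Without a bearing step, the expectation for compound 4 in this assay is a step of no particular direction and not beyond the scatter, a 1.1-fold lower number from compound 3 to compound 4 (0.04 log units; within the scatter), with a wide range. Compound 4 is therefore estimated at 30000 nM, between 8000 nM and 110000 nM.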

Compound 4, concentration for 50% growth inhibition: 29000 nM
Beside the measured number, compound 4's estimate is 1.0-fold (0.01 log units) above it; the measured number falls inside the stated range.
By their numbers in this assay, from the lowest: compound 2; then compounds 4, 3 and 1 (each within the scatter of the next).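

Among the compounds shown here, this is the first measured change at the saturated chain carbon bound to an amide-type nitrogen. In this assay, placing 3,4-dichlorophenyl where 4-methoxyphenyl stood gives a 1.1-fold lower number from compound 3 to compound 4 (0.06 log units; within the scatter) and leaves the two compounds indistinguishable, even though the methoxy oxygen is gone, chlorine enters and the count of hydrogen-bond acceptors differs, so at this position, on this one pair, these two groups cannot be told apart by growth inhibition. Nothing measured here speaks to why that is so.

For the compounds shown here, whether the same holds with the 5-chlorofuran-2-yl group of compound 2 remains open, since this change is seen only with the aromatic group of compound 3. Also open, on these data alone, is how a carboxylic acid, an amine or a longer chain would behave in place of the aromatic ring at this position.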